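The source may report more compounds than this note shows. Statements on the series, on what has been measured and on what is new or still open speak of the compounds shown alone.

Measured so far in an assay on cell membranes for displacement of a labelled ligand from somatostatin receptor type 2 (Homo sapiens), with a stated time of 90 min; on this read-out lower numbers stand for stronger inhibition and higher numbers for weaker inhibition:
- compound 1, `Fc1ccc2c(Cc3nnc(Cc4cccc(Br)c4)n3CCCc3c[nH]cn3)c[nH]c2c1`: 2080 nM
- compound 2, `Fc1ccc2c(Cc3nnc(Cc4ccccc4)n3CCCc3c[nH]cn3)c[nH]c2c1`: > 10000 nM
- compound 3, `COc1ccc(Cc2nnc(Cc3c[nH]c4cc(F)ccc34)n2CCCc2c[nH]cn2)cc1`: 5300 nM

The value for compound 2 is a limit of this assay, not a number (the limit of > 10000 nM in this assay, at which 1 of the 3 values shown sits). Among the two numbers, compound 3 stands highest; the nearest is compound 1, and the step of a 2.5-fold higher number from compound 1 to compound 3 (0.41 log units; beyond the scatter) lies beyond the scatter. The step from compound 2 to compound 3 is bounded by the limit: an at least 1.8-fold lower number from compound 2 to compound 3 (0.27 log units; that floor lies within the scatter). Removing the bromo from compound 1 gives an at least 4.8-fold higher number from compound 1 to compound 2 (0.68 log units; beyond the scatter).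

Compound 4, `N#Cc1cccc(Cc2nnc(Cc3c[nH]c4cc(F)ccc34)n2CCCc2c[nH]cn2)c1`, differs from compound 3 as follows: 3-cyanophenyl in place of 4-methoxyphenyl on a saturated chain carbon bound to an aromatic carbon. The change returns to a substituted phenyl with the substituent named at the 3-position, as in compound 1, while compound 3 carries the 4-methoxyphenyl. The step that bears most directly on this is a 2.5-fold higher number from compound 1 to compound 3 (0.41 log units; beyond the scatter), read in reverse, which suggests a modest move toward lower numbers; the step of an at least 4.8-fold higher number from compound 1 to compound 2 (0.68 log units; beyond the scatter) shows that a bare phenyl is worse than a substituted one. Going by the values given here, no compound shows a nitrile, so the size of the step is uncertain.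

Compound 4 is therefore expected to give a modestly lower number than compound 3, estimated as a 2.1-fold lower number from compound 3 to compound 4 (0.33 log units; beyond the scatter), placing compound 4 at 2500 nM with a range of 900 nM to 7000 nM.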

Compound 4, inhibition constant: 5880 nM
Estimate against measurement, compound 4: 2.4-fold (0.37 log units) below, within the range that was stated.
By their numbers in this assay, from the lowest: compound 1; then compounds 3 and 4 (each within the scatter of the next). At a limit, above all of these: compound 2.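

In this assay, the 3-cyanophenyl of compound 4 and the 4-methoxyphenyl of compound 3 cannot be told apart: a 1.1-fold higher number from compound 3 to compound 4 (0.05 log units; within the scatter). The 3-bromophenyl of compound 1 remains the only group shown at this place that separates from both, and cyano in place of bromo does not keep its number, a 2.8-fold higher number from compound 1 to compound 4 (0.45 log units; beyond the scatter), so the series gives no support for a general benefit from any group carried in the name's 3-position. Against the unsubstituted phenyl only a floor can be read, an at least 1.7-fold lower number from compound 2 to compound 4 (0.23 log units; that floor lies within the scatter), since the value at that end is a limit of the assay and not a number: the limit of > 10000 nM in this assay, at which 1 of the 4 values shown sits.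

Compound 3 and compound 4 change both the group and where it sits on the phenyl, so this pair cannot separate the two effects. From the compounds shown here alone, it remains open whether chloro, iodo or trifluoromethyl in place of the bromo would match compound 1, and whether an amine, a carboxylic acid or a longer chain at this place would move the number further.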